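The compounds below may be only part of what the source reports. "The series", "measured", "known", "first", "only" and "open" are said of these compounds alone.

Compound 1 `CCCOC(=O)C1=C(C)NC(=S)NC1c1ccoc1` and compound 2 `CC1=C(C(=O)OCC(C)C)C(c2ccoc2)NC(=S)N1` share one core, while compound 3 `CCCOC(=O)C1=C(C)N(C)C(=O)NC1c1ccco1` is built on a core of a different kind; the difference between the two cores is not broken down here. In an assay on membranes from HeLa cells for displacement of a labelled ligand from adenosine receptor A3 (Homo sapiens), read by scintillation counting, with a stated time of 180 min, tested at 1 uM (a higher number here means more inhibition at the concentration tested (going by the name of the read-out), a lower number less inhibition), compound 1 gives 3% and compound 2 gives 1%. Going by the values given here, the only change between these two is methyl in place of hydrogen on a saturated chain carbon bound to two saturated chain carbons, and it gave a number 2 percentage points lower from compound 1 to compound 2 (within the scatter). In this assay compound 3 gives 8%; this value and the values of compound 1 and compound 2 all lie within the usual scatter of one another, so none of the three can be set apart from the others.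

Compound 4 `CC1=C(C(=O)OCC(C)C)C(c2ccco2)NC(=O)N1C` has not yet been measured. It arises from compound 3 through the same change that turns compound 1 into compound 2: methyl in place of hydrogen on a saturated chain carbon bound to two saturated chain carbons, at the same kind of place in the molecule. Because the matching step a number 2 percentage points lower from compound 1 to compound 2 (within the scatter) stayed within the scatter, the expected outcome is that compound 4 will also stay close to compound 3 in this assay. The step expected here is a number 1 percentage points lower from compound 3 to compound 4 (within the scatter). The estimate for compound 4 in this assay is 7%, with a likely range from 0% to 18%.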

Compound 4, a percentage reported as inhibition, at one concentration (the size of the read-out at that concentration, not a potency): 23%
For compound 4 the middle estimate is 16 percentage points below the measured one, outside the stated range (above it).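

In this assay, replacing a hydrogen with a methyl on a saturated chain carbon bound to two saturated chain carbons, which turns the propoxy group into an isobutoxy group, gave a number 15 percentage points higher from compound 3 to compound 4 (beyond the scatter). The same change therefore did not behave alike on the two cores, and the small step seen on the first core proved no safe guide to the step on the second: the same change on two cores in this assay, a number 2 percentage points lower (within the scatter) from compound 1 to compound 2 and a number 15 percentage points higher (beyond the scatter) from compound 3 to compound 4, 17 percentage points apart, beyond the scatter of two such steps. Going by these compounds alone, this shows that, for these two pairs of compounds, the outcome of the change cannot simply be carried from one core to the other, but it does not show why, nor does it give a general rule for the series, as each core offers only one pair and each reading is an inhibition at a single concentration rather than a potency.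

The compounds shown leave open which of the differences between the two cores goes with this split, as those differences are not separated here by compounds that differ in one place. They also leave open how a longer chain such as butoxy, or a carboxylic acid in place of the ester, would read in this assay on either core.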